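Adding a methyl to the core of compound 1

The source may report more compounds than this note shows. Statements on the series, on what has been measured and on what is new or still open speak of the compounds shown alone.

Compound 1, with the structure `CCCOC(=O)c1[nH]cc(C(=O)OC(C)C(C)(C)C)c1C`, is the starting point. In an assay on CHO cells for inhibition of metabotropic glutamate receptor 1 (Rattus norvegicus) (a higher number here means a weaker inhibitor, a lower number a stronger inhibitor), compound 1 gives 4 nM, the lowest of the two numbers recorded so far. Among the measured compounds shown here, the only other measured compound, compound 2 with the structure `CCCOC(=O)c1[nH]cc(C(=O)OC(C)(C)C)c1C`, gives 75 nM in this assay; the single known step is a 19-fold higher number from compound 1 to compound 2 (1.27 log units; beyond the scatter), which concerns the ester group on the oxygen and leaves the ring untouched.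

Compound 3, with the structure `CCCOC(=O)c1[nH]c(C)c(C(=O)OC(C)C(C)(C)C)c1C`, differs from compound 1 only at the ring: methyl in place of hydrogen on an aromatic carbon. The change is a small one on an aromatic carbon next to the ring nitrogen, while the two ester groups stay exactly as in compound 1.

For the measured compounds named here, no measured step bears on this change. The step from compound 1 to compound 2 altered a different part of the molecule, so it gives no guide to what a methyl on the ring will do. The expectation is therefore a small step, in either direction, a 2.0-fold higher number from compound 1 to compound 3 (0.30 log units; within the scatter), with wide uncertainty. Compound 3 is estimated to give 8 nM in this assay, within a range from 2 nM to 40 nM.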

Compound 3, half-maximal inhibitory concentration: 15800 nM
Compound 3: middle estimate off by 2000-fold (3.30 log units), on the low side, outside the stated range (above it).
By their numbers in this assay, from the lowest: compound 1; then compound 2; then compound 3.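

In this assay, a single added methyl gives a 4000-fold higher number from compound 1 to compound 3 (3.60 log units; beyond the scatter), so this aromatic carbon next to the ring nitrogen proves highly sensitive to change: replacing one hydrogen with one carbon-bearing group is enough to turn a strong inhibitor into a very weak one. The earlier step, a 19-fold higher number from compound 1 to compound 2 (1.27 log units; beyond the scatter), concerned only the ester group on the oxygen and revealed nothing about the ring, whereas this result shows that the ring also responds strongly, and to an even smaller edit. Nothing available here explains why the methyl has so large an effect.

Among the compounds shown, this carbon carries only hydrogen or methyl, so it remains open whether a smaller atom such as fluorine, or a larger group such as ethyl or hydroxymethyl, would give a number close to that of compound 1 or of compound 3. From the compounds shown here alone, it also remains open whether the same methyl would produce a step of similar size on compound 2, with its tert-butyl ester.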